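Replacing trifluoromethyl with phenoxy: what size of step?

The source may hold more compounds than are shown below. What is called first, only, known or untested is meant among the compounds shown, and "the series" means these compounds.

Measured in a functional assay on DU-145 cells (Homo sapiens) for inhibition, read by CCK-8 assay, with a stated time of 72 h; on this read-out lower numbers stand for stronger inhibition and higher numbers for weaker inhibition:
- compound 1 `O=C(/C=C/c1cccnc1)NCCCCCCc1cccc(S(=O)(=O)Nc2ccc(Cl)cc2)c1`: 84.4 nM
- compound 2 `O=C(/C=C/c1cccnc1)NCCCCCCc1cccc(S(=O)(=O)Nc2ccc(F)cc2)c1`: 10.6 nM
- compound 3 `O=C(/C=C/c1cccnc1)NCCCCCCc1cccc(S(=O)(=O)Nc2ccc(C(F)(F)F)cc2)c1`: 1410 nM

Of these three, compound 3 has the highest number at 1410 nM, which makes it the weakest inhibitor here. Compound 4 `O=C(/C=C/c1cccnc1)NCCCCCCc1cccc(S(=O)(=O)Nc2ccc(Oc3ccccc3)cc2)c1` keeps the rest of compound 3 and changes a single group, with phenoxy in place of trifluoromethyl on an aromatic carbon.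

For the measured compounds named here, no compound with phenoxy has been measured, so the best guide is what earlier swaps of this one group did. These swaps gave an 8.0-fold lower number from compound 1 to compound 2 (0.90 log units; beyond the scatter), a 17-fold higher number from compound 1 to compound 3 (1.22 log units; beyond the scatter) and a 130-fold higher number from compound 2 to compound 3 (2.12 log units; beyond the scatter), all beyond the scatter. The number rises from the fluoro compound through the chloro compound to the trifluoromethyl compound, and none of the three goes against that order. Whether phenoxy would continue this rise cannot be told from these data.

With a 17-fold higher number from compound 1 to compound 3 (1.22 log units; beyond the scatter) in view, compound 3 sits at the high end of the range seen so far, so a moderate fall in this assay seems more likely than a further rise, though with wide uncertainty. The expected change is a 2.8-fold lower number from compound 3 to compound 4 (0.45 log units; beyond the scatter). For compound 4 the estimated value is 500 nM, with an expected range from 60 nM to 4000 nM.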

Compound 4, half-maximal inhibitory concentration: 50.9 nM
Compound 4: the middle estimate sits 9.8-fold (0.99 log units) above what was measured; the whole stated range lies above it.
By their numbers in this assay, from the lowest: compound 2; then compounds 4 and 1 (each within the scatter of the next); then compound 3.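

In this assay, this position on the aromatic ring accepts a group that brings a second ring, and a 28-fold lower number from compound 3 to compound 4 (1.44 log units; beyond the scatter) shows that a bulkier replacement can recover much of what trifluoromethyl lost. Phenoxy has 7 heavy atoms against 4 for trifluoromethyl, so compound 4 goes against the rise from fluoro through chloro to trifluoromethyl, and a greater heavy-atom count does not by itself bring a higher number here. Even so, phenoxy does not match the small fluoro group, with a 4.8-fold higher number from compound 2 to compound 4 (0.68 log units; beyond the scatter), while a 1.7-fold lower number from compound 1 to compound 4 (0.22 log units; within the scatter) means that phenoxy and chloro cannot be told apart in this assay.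

From the compounds shown here alone, it remains open how a methoxy group, an amine or a benzyloxy group at this same place would compare, and whether adding a substituent to the outer ring of phenoxy would move the number in either direction. The results shown come with no separate measurement that could explain why these groups differ as they do.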